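Chlorinated Phenyl on the Sulfonyl Sulfur of an Agonist

The compounds below may be only part of what the source reports. "The series", "measured", "known", "first", "only" and "open" are said of these compounds alone.

Measured compounds:
compound 1, `CN(C)CCn1cc(S(=O)(=O)c2ccccc2)c2cccnc21`, 25 nM
compound 2, `Cc1c(S(=O)(=O)c2ccccc2)c2cccnc2n1CCN(C)C`, 47 nM
compound 3, `O=S(=O)(c1cccc(F)c1)c1cn(CCN2CCCC2)c2ncccc12`, "not determined" (no result reported)

In a functional assay on HeLa cells for agonist activity at 5-hydroxytryptamine receptor 6 (Homo sapiens), read by immunoassay (a higher number here means that more compound is needed for the effect, a lower number that less compound is needed), compound 1 gives 25 nM and compound 2 gives 47 nM; compound 3 gives "not determined" (no result reported) in this assay. Going by the values given here, compound 1 thus stands on one of only two numbers, and the single step, a 1.9-fold higher number from compound 1 to compound 2 (0.27 log units; within the scatter), lies within the scatter, so nothing in these data separates the two.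

Compound 4, `CN(C)CCn1cc(S(=O)(=O)c2cc(Cl)cc(Cl)c2)c2cccnc21`, differs from compound 1 in one place: 3,5-dichlorophenyl in place of phenyl on a sulfonyl sulfur. Among the compounds with values here, no measured step touches the group on the sulfonyl sulfur: the only step recorded is a methyl for a hydrogen on an aromatic carbon, and compound 3, which carries a different substituted phenyl there, has no value. The change is therefore unsupported by any step, and no shift beyond the scatter is expected in this assay in either direction. The estimate for compound 4 is 30 nM, with a range from 8 nM to 120 nM. The step this implies, a 1.2-fold higher number from compound 1 to compound 4 (0.08 log units; within the scatter), is expected to stay within the scatter.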

Compound 4, half-maximal effective concentration: 28 nM
For compound 4 the middle estimate is 1.1-fold (0.03 log units) above the measured one; low and high end bracket the measured number.
By their numbers in this assay, from the lowest: compounds 1, 4 and 2 (each within the scatter of the next).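

In this assay, going by these compounds alone, no earlier step had touched the group on the sulfonyl sulfur, and compound 3, with a different substituted phenyl there, gave no number, so a 1.1-fold higher number from compound 1 to compound 4 (0.05 log units; within the scatter) is the first reading at this position. It shows that replacing phenyl with 3,5-dichlorophenyl, which takes the group from 6 to 8 heavy atoms and adds two chlorine atoms, leaves the number within the scatter on the core of compound 1. Nothing measured here offers an explanation for this result.

The compounds shown leave open whether a phenyl carrying a single chlorine, a methoxy group or a carboxylic acid would also stay within the scatter. They also leave open whether 3,5-dichlorophenyl would give a similar number alongside the methyl group of compound 2.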